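This account rests on a few compounds, and the source may have more. Where it says the series, first, only, none or still open, it means among the compounds named here.

Compound 1 `O=S(=O)(/C=C/c1ccc(C(F)(F)F)cc1F)Cc1ccc(Nc2ncnc3ccccc23)cc1`: 100000 nM
Compound 2 `O=S(=O)(/C=C/c1ccc(Cl)cc1Cl)Cc1ccc(Nc2ncnc3ccc(Br)cc23)cc1`: 4000 nM

In a functional assay on PC-3 cells (Homo sapiens) (on this read-out lower numbers stand for stronger inhibition of growth and higher numbers for weaker inhibition of growth), compound 2 has the lower of the two numbers, and its gap to compound 1 lies beyond the usual scatter. Compound 3 `O=S(=O)(/C=C/c1ccc(C(F)(F)F)cc1F)Cc1ccc(Nc2ncnc3ccc(Br)cc23)cc1` has not yet been measured. It differs from compound 2 in a single place: 2-fluoro-4-(trifluoromethyl)phenyl stands in place of 2,4-dichlorophenyl on a double-bonded chain carbon bound to a double-bonded chain carbon (2-fluoro-4-(trifluoromethyl)phenyl in place of 2,4-dichlorophenyl on a double-bonded chain carbon bound to a double-bonded chain carbon).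

Compound 1 carries the same 2-fluoro-4-(trifluoromethyl)phenyl group and gives 100000 nM, which might suggest a loss. However, compound 1 differs from compound 2 in more than this group, so the two values cannot show what the exchange alone does. Within the data shown here, no measured pair isolates this change, and the expectation is therefore cautious and anchored on compound 2 at 4000 nM. The expected step is small, a 1.5-fold higher number from compound 2 to compound 3 (0.18 log units; within the scatter), leaning slightly towards weaker inhibition of growth but not expected to go beyond the scatter. For compound 3 the estimated value is 6000 nM, with an expected range from 1500 nM to 25000 nM.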

Compound 3, concentration for 50% growth inhibition: 58000 nM
Beside the measured number, compound 3's estimate is 9.7-fold (0.99 log units) below it; the whole stated range lies below it.
By their numbers in this assay, from the lowest: compound 2; then compounds 3 and 1 (each within the scatter of the next).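

In this assay, the exchange of 2,4-dichlorophenyl for 2-fluoro-4-(trifluoromethyl)phenyl on a double-bonded chain carbon bound to a double-bonded chain carbon can now be read on its own, and it gives a 15-fold higher number from compound 2 to compound 3 (1.16 log units; beyond the scatter) in a single step, so this position is clearly sensitive to which substituted phenyl group it carries. With 2-fluoro-4-(trifluoromethyl)phenyl held in place, bromo in place of hydrogen on an aromatic carbon gives a 1.7-fold lower number from compound 1 to compound 3 (0.24 log units; within the scatter) and so shows no change that can be told from the scatter. No measurement at hand offers a reason for the size of the step at the phenyl group.

The compounds shown leave open what bromo in place of hydrogen does when 2,4-dichlorophenyl is present, as no pair here reads that change. They also leave open which part of the exchange carries the step, and how this position would respond to a phenyl group bearing a methoxy or a nitrile instead of halogens.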